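Three Compounds at the Assay Limit, a Fourth Untested

The source may hold more compounds than are shown below. What is called first, only, known or untested is meant among the compounds shown, and "the series" means these compounds.

The measured compounds:
compound 1 `Cc1ccc(-c2nnc(SCCCN3CCN(c4cccc(Cl)c4)CC3)[nH]2)cc1` gives > 300000 nM
compound 2 `Clc1ccc(-c2nnc(SCCCN3CCN(c4cccc(Cl)c4)CC3)[nH]2)cc1` gives > 300000 nM
compound 3 `Cc1ccc(-c2nn(CCCN3CCN(c4cccc(Cl)c4)CC3)c(=S)[nH]2)cc1` gives > 300000 nM

All three were tested in a functional assay on HL-60 cells (Homo sapiens) for cytotoxicity, read by MTT assay, with a stated time of 24 h; a lower number here means a stronger inhibitor, a higher number a weaker inhibitor. For compound 1 the value is a limit of the assay, not a number. For compound 2 the value is likewise a limit. For compound 3 the value is again a limit. Compound 1 and compound 2 differ in one place, (chloro in place of methyl on an aromatic carbon), yet the step that the two limits leave unreadable from compound 1 to compound 2 cannot be read, since both ends sit at the limit. Compound 3 has the same atoms as compound 1, joined differently; the difference between the two cores is not broken down here.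

Compound 4 `S=c1[nH]c(-c2ccc(Cl)cc2)nn1CCCN1CCN(c2cccc(Cl)c2)CC1` is not yet measured. It stands to compound 3 as compound 2 stands to compound 1: the change is chloro in place of methyl on an aromatic carbon, the same change at the same place. Because the limit of > 300000 nM in this assay, at which 3 of the 3 values shown sit, holds for every compound shown, the step from compound 1 to compound 2 gives no size to carry over, and the step that the limit leaves unreadable from compound 3 to compound 4 is expected to be likewise unreadable, with compound 4 most probably returning only a limit in this assay. Compound 4 is therefore estimated at 400000 nM, with a range from 100000 nM to 2000000 nM.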

Compound 4, half-maximal inhibitory concentration: 6670 nM
Compound 4: middle estimate off by 60-fold (1.78 log units), on the high side; the measured number lies below the stated range.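

In this assay, within the data shown here, putting chloro in place of methyl on the core of compound 3 gives an at least 44-fold lower number from compound 3 to compound 4 (1.65 log units; beyond the scatter), so on this core the change from 4-methylphenyl to 4-chlorophenyl is large, and compound 4, at 6670 nM, is the only compound of the four with a real number rather than a limit. The same change on the core of compound 1 cannot be read, since the step to compound 2 runs from one limit to another, and neither end gives a number: the limit of > 300000 nM in this assay, at which 3 of the 4 values shown sit. What this shows is one clear result on one core, from a single pair of compounds; it does not show that the change carries over to the core of compound 1, nor that it fails to, since compound 2 could lie anywhere past its limit.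

The compounds shown leave open whether another group at the same place on the ring, such as bromo, fluoro or methoxy, would also give a number well inside the range of the assay. They also leave open whether a longer chain, or an amine on the aromatic ring, would lift the core of compound 1 off its limit so that the two cores could be compared directly.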